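Amino acid substitution on the core of compound 1

The compounds below may be only part of what the source reports. "The series", "measured", "known", "first", "only" and "open" are said of these compounds alone.

Measured in a functional assay on Fem-X cells (Homo sapiens) for cytotoxicity, read by MTT assay, with a stated time of 72 h; a lower number here means a stronger inhibitor, a higher number a weaker inhibitor
- compound 1 `CC1=CCC[C@H]2[C@](C)(CC3=CC(=O)C=CC3=O)[C@@H](C)CC[C@]12C` gives 40300 nM
- compound 2 `CC(C)C[C@H](NC1=CC(=O)C=C(C(C)(C)C)C1=O)C(=O)O` gives 39400 nM

Compound 1 stands level with compound 2, the two values lying within the scatter of each other. Compound 3 `CC1=CCC[C@H]2[C@](C)(CC3=CC(=O)C=C(N[C@@H](C(=O)O)C(C)C)C3=O)[C@@H](C)CC[C@]12C`, not yet measured, has (1-carboxy-2-methylpropyl)amino in place of hydrogen on a double-bonded ring carbon on the core of compound 1, (1-carboxy-2-methylpropyl)amino in place of hydrogen on a double-bonded ring carbon. Going by the values given here, no measured step in this assay covers this change. Compound 2 also bears an amino group with a carboxy-carrying chain and gives 39400 nM as its value, so no step beyond the scatter is expected. The estimated step is a 1.3-fold lower number from compound 1 to compound 3 (0.13 log units; within the scatter) and is expected to stay within the scatter. For compound 3 the estimated value is 30000 nM with an expected range from 10000 nM to 60000 nM as the working figure.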

Compound 3, half-maximal inhibitory concentration: 11400 nM
Beside the measured number, compound 3's estimate is 2.6-fold (0.42 log units) above it, within the range that was stated.
By their numbers in this assay, from the lowest: compound 3; then compounds 2 and 1 (each within the scatter of the next).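

Replacing hydrogen with (1-carboxy-2-methylpropyl)amino on this double-bonded ring carbon gives a 3.5-fold lower number from compound 1 to compound 3 (0.55 log units; beyond the scatter) in this assay and provides the first step read at this position. The change thus moves the number beyond the scatter on the core of compound 1, though the step remains modest. Nothing measured here explains the step.

On these data alone, it remains open whether the carboxylic acid is needed for this step, or whether a plain amine at this carbon would give a similar number. The effect of a longer amino acid chain is also unresolved.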